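The compounds below may be only part of what the source reports. "The series", "measured", "known", "first", "only" and "open" are said of these compounds alone.

Compound 2, `Brc1ccc(-c2cn3ccnc3c(-c3ccc4ncn(C5CCCCC5)c4c3)n2)cc1`, gives 10.5% in a functional assay on OVCAR-4 cells (Homo sapiens) for inhibition, read by sulforhodamine B assay, with a stated time of 48 h, tested at 10 uM (on this read-out higher numbers stand for more inhibition at the one concentration tested (going by the name of the read-out) and lower numbers for less inhibition), which is the higher of the two numbers recorded, with compound 1, `Fc1ccc(-c2cn3ccnc3c(-c3ccc4ncn(C5CCCCC5)c4c3)n2)cc1`, nearest to it at 5.73%; the difference between them lies within the scatter. Among the compounds with values here, the only measured step, a number 4.8 percentage points higher from compound 1 to compound 2 (within the scatter), is the one that bears on the present question, and it shows no change beyond the scatter.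

Compound 3, `Fc1ccccc1-c1cn2ccnc2c(-c2ccc3ncn(C4CCCCC4)c3c2)n1`, is not yet measured. It differs from compound 2 by 2-fluorophenyl in place of 4-bromophenyl on an aromatic carbon. Within the data shown here, since the one step that exchanges the substituent on this ring, from compound 1 to compound 2, stayed within the scatter, no step beyond the scatter is expected here either, and compound 3 is estimated to remain at the low level of compound 2 and compound 1. The expected step is a number 3.5 percentage points lower from compound 2 to compound 3 (within the scatter). The estimate for compound 3 is 7%, with a range from -8% to 22%.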

Compound 3, a percentage reported as inhibition, at one concentration (the size of the read-out at that concentration, not a potency): 4.51%
For compound 3 the middle estimate is 2.5 percentage points above the measured one; low and high end bracket the measured number.
By their numbers in this assay, from the lowest: compounds 3, 1 and 2 (each within the scatter of the next).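

In this assay, 2-fluorophenyl in place of 4-bromophenyl gives a number 6 percentage points lower from compound 2 to compound 3 (within the scatter), and 2-fluorophenyl in place of 4-fluorophenyl gives a number 1.2 percentage points lower from compound 1 to compound 3 (within the scatter). The earlier compounds shown here showed only that exchanging one halogen for another on the phenyl ring made no difference beyond the scatter; these steps show the same for a change in where the fluorine sits on that ring, so all three phenyl groups at this position on the shared core give numbers within the scatter of one another. Nothing available here explains this lack of separation.

The compounds shown leave open whether a phenyl ring carrying an amine or a carboxylic acid would move the number beyond the scatter. They also leave open whether replacing the phenyl ring with a longer alkyl chain would do so.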